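A methyl added to compound 2

The source may report more compounds than this note shows. Statements on the series, on what has been measured and on what is new or still open speak of the compounds shown alone.

In a functional assay on the whole organism for agonist activity, with Mus musculus as the target (a higher number here means that more compound is needed for the effect, a lower number that less compound is needed), compound 2 `CC(C#CCn1ccnc1)N1CCCC1=O` gives only the limit > 100 mg/kg as its read-out. Compound 3 `Cc1cncn1CC#CC(C)N1CCCC1=O` is compound 2 with methyl in place of hydrogen on an aromatic carbon. Compound 1 `CC(=O)N(C)C(C)C#CCn1cncc1C` also carries a methyl on an aromatic carbon, and it too gives only the limit > 100 mg/kg as its read-out. The data therefore stand at the limit of > 100 mg/kg in this assay, at which 2 of the 2 values shown sit, and hold no number. The expected step that the limit leaves unreadable from compound 2 to compound 3 in this assay lies within the scatter, with no clear direction, and another limit is likely. Compound 3 is estimated at 120 mg/kg with an expected range of 40 mg/kg to 300 mg/kg for the dose.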

Compound 3, dose for half-maximal effect: > 100 mg/kg
Compound 3 ended at the assay's limit; the forecaster's own chance of this, stated with the estimate: 70%; the middle value is on the limit's open side.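

In this assay no step can be read from compound 2 to compound 3, since both sit at a limit of the assay: the limit of > 100 mg/kg in this assay, at which 3 of the 3 values shown sit.

The compounds shown leave open whether the added methyl changes the dose needed for half-maximal effect.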